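Removing a Methoxy Group from an Indole Chalcone

A few compounds are considered here, and "the series" means these few. Any claim that something is new, unique, unknown or untested is made for them only; others in the source may bear on it.

Compound 1, `COc1ccc2c(/C=C/C(=O)c3cc(OC)c(OC)c(SC)c3)cn(C)c2c1`, gives 167 nM in a functional assay on HeLa cells (Homo sapiens) for antiproliferative activity, read by MTT assay, with a stated time of 48 h; a lower number here means a stronger inhibitor, a higher number a weaker inhibitor. Compound 2, `COc1ccc2c(/C=C(\C)C(=O)c3cc(OC)c(OC)c([Se]C)c3)c[nH]c2c1`, gives 21 nM in this assay. Compound 3, `COc1cc(C(=O)/C(C)=C/c2c[nH]c3ccccc23)cc([Se]C)c1OC`, gives 34 nM in this assay.

Among the three measured compounds, compound 1 stands with the highest number; its values against compound 2 and compound 3 both lie beyond the usual scatter of this kind of measurement. Compound 2 and compound 3 differ in one place only, (hydrogen in place of methoxy on an aromatic carbon), and that change made a 1.6-fold higher number from compound 2 to compound 3 (0.21 log units; within the scatter), a step that stays within the scatter. Compound 1 and compound 2 differ in more than one place, and the difference between the two cores is not broken down here.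

Compound 4, `COc1cc(C(=O)/C=C/c2cn(C)c3ccccc23)cc(SC)c1OC`, has not yet been measured. It differs from compound 1 in exactly the same way that compound 3 differs from compound 2: hydrogen in place of methoxy on an aromatic carbon. Because a 1.6-fold higher number from compound 2 to compound 3 (0.21 log units; within the scatter) was a small step, the expectation for compound 4 is a step of similar size and direction, a 1.5-fold higher number from compound 1 to compound 4 (0.18 log units; within the scatter). This rests on a single precedent, so the range is kept wide. Compound 4 is therefore expected to give about 250 nM in this assay, most likely between 120 nM and 550 nM.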

Compound 4, half-maximal inhibitory concentration: 105 nM
For compound 4 the middle estimate is 2.4-fold (0.38 log units) above the measured one, outside the stated range (below it).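

Removing the methoxy group from the core of compound 1 gave a 1.6-fold lower number from compound 1 to compound 4 (0.20 log units; within the scatter) in this assay, so compound 4 cannot be told apart from compound 1 in this read-out. The same swap on the other core gave a step that also lies within the scatter, and the two steps can be regarded as agreeing even though their printed numbers point in opposite directions: the same change on two cores in this assay, a 1.6-fold higher number (0.21 log units; within the scatter) from compound 2 to compound 3 and a 1.6-fold lower number (0.20 log units; within the scatter) from compound 1 to compound 4, 2.6-fold (0.41 log units) apart, within the scatter of two such steps. Going by these compounds alone, this shows that, in these two pairs, the methoxy group can be replaced by hydrogen without a change larger than the usual scatter, but it gives no direction for the step and, resting on two pairs alone, it sets no rule for other cores.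

The compounds shown carry only methoxy or hydrogen at this place, so it remains open whether a larger change there, such as a hydroxyl group, an amine or a longer chain like butoxy, would move the number beyond the scatter. Also open is which of the several differences between compound 1 and compound 2 accounts for the distance between their values, since no pair shown isolates any one of them.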